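The source may hold more compounds than are shown below. What is called first, only, known or untested is meant among the compounds shown, and "the series" means these compounds.

Going by the values given here, compound 2 `CO[C@H]1CC[C@H](NC(=O)c2n[nH]cc2NC(=O)c2ccc(F)cc2F)CC1` is the one compound among the three measured that returns a number in an ADME assay on MRC5 cells (Homo sapiens) for inhibition, with a stated time of 72 h; a higher number here means that more compound is needed for the effect, a lower number that less compound is needed: compound 2 gives 11000 nM. Compound 1 `COc1cccc(OC)c1C(=O)Nc1c[nH]nc1C(=O)Nc1ccncc1` stops at a limit of this assay, and compound 1 gives > 50000 nM. Compound 3 `COc1cccc(OC)c1C(=O)Nc1c[nH]nc1C(=O)NCc1ncccc1C` likewise stops at a limit; compound 3 gives > 50000 nM. Among the compounds with values here, the only measured step, a step that the two limits leave unreadable from compound 1 to compound 3, has no readable size because both of its ends sit at the limit of > 50000 nM in this assay, at which 2 of the 3 values shown sit.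

Compound 4 `CO[C@H]1CC[C@H](NC(=O)c2n[nH]cc2NC(=O)c2ccccc2F)CC1` differs from compound 2 by hydrogen in place of fluoro on an aromatic carbon. No measured step covers a change of this kind, and the single step shown yields no size at all, so the numbers give no indication of movement beyond the usual scatter in either direction. The step from compound 2 to compound 4 is therefore expected to be a 1.2-fold higher number from compound 2 to compound 4 (0.07 log units; within the scatter). Compound 4 is estimated to give 13000 nM in this assay, with a range from 5000 nM to 40000 nM, and a real chance that only a limit is returned.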

Compound 4, half-maximal effective concentration: 1000 nM
Compound 4: middle estimate off by 13-fold (1.11 log units), on the high side; measured number outside the range, below it.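

In this assay, going by these compounds alone, the change from 2,4-difluorophenyl to 2-fluorophenyl gives an 11-fold lower number from compound 2 to compound 4 (1.04 log units; beyond the scatter) and is the first step of readable size, since the only earlier step cannot be read. The aromatic carbon para to a large group is thus a place where exchanging a single fluoro group for hydrogen moves the number well beyond the scatter, with less compound needed once the fluoro group has left. Nothing at hand accounts for the size of this step.

As far as these compounds go, whether a chloro, methoxy or amine group at this place would give a number nearer compound 2 or compound 4 remains open. Also open, from the compounds shown here alone, is whether the remaining fluoro group, meta to this place, matters to a similar degree.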